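Swapping the sulfonamide substituent on compound 1

A few compounds are considered here, and "the series" means these few. Any claim that something is new, unique, unknown or untested is made for them only; others in the source may bear on it.

compound 1 `Cc1cc(C)nc(NS(=O)(=O)c2ccc(Nc3nncc4ccccc34)cc2)n1`: 7.7 nM
compound 2 `C(=C/c1ccccc1)\C(=N\Nc1nncc2ccccc12)c1ccccc1`: 2.2 nM

In a functional assay on MCF7 cells (Homo sapiens) for antiproliferative activity, read by sulforhodamine B assay, with a stated time of 72 h (a higher number here means a weaker inhibitor, a lower number a stronger inhibitor), compound 1 gives the higher of the two numbers, 7.7 nM, while compound 2 gives 2.2 nM, a gap beyond the usual scatter. Compound 3 `Cc1cc(NS(=O)(=O)c2ccc(Nc3nncc4ccccc34)cc2)no1` carries 5-methyl-1,2-oxazol-3-yl in place of 4,6-dimethylpyrimidin-2-yl on a sulfonamide nitrogen. Among the compounds with values here, no measured pair shows this change, so its size in this assay cannot be read from data. The estimate is a step of a 1.3-fold higher number from compound 1 to compound 3 (0.11 log units; within the scatter), expected to stay within the scatter, with no firm direction. The estimated value for compound 3 is 10 nM, with an expected range of 3 nM to 35 nM.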

Compound 3, half-maximal inhibitory concentration: 46 nM
Beside the measured number, compound 3's estimate is 4.6-fold (0.66 log units) below it; measured number outside the range, above it.
By their numbers in this assay, from the lowest: compound 2; then compound 1; then compound 3.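

In this assay, the substituent on the sulfonamide nitrogen is not a neutral handle: 5-methyl-1,2-oxazol-3-yl in place of 4,6-dimethylpyrimidin-2-yl gives a 6.0-fold higher number from compound 1 to compound 3 (0.78 log units; beyond the scatter). This single step changes ring size, heavy-atom count and hetero atoms together, so it cannot assign the shift to any one of them. Nothing measured here accounts for the weaker result.

Still open, from the compounds shown here alone, is whether a plain phenyl or an unsubstituted pyrimidin-2-yl would keep the number of compound 1. Also open, going by these compounds, is how a small alkyl group such as methyl on this nitrogen would compare.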